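The source may hold more compounds than are shown below. What is called first, only, known or untested is meant among the compounds shown, and "the series" means these compounds.

Working notes on the series. In an in vitro ADME assay on microsomes from liver (Homo sapiens) for metabolic stability (on this read-out higher numbers stand for fast clearance and lower numbers for slow clearance), compound 1 (`Cc1nnc(C2CCN(c3ccccn3)CC2)n1-c1ccc(Cl)cc1`) gives 23 mL.min-1.g-1. Compound 2 (`Cc1nnc(C2CCN(c3ccccn3)CC2)n1Cc1ccccc1`) gives < 8 mL.min-1.g-1, which is a limit of the assay and not a number. From the compounds shown here alone, its true position therefore remains open, and any step starting from it carries that uncertainty.

Compound 3 (`c1ccc(Cn2c(Cn3nccn3)nnc2C2CCN(c3ccccn3)CC2)cc1`) keeps the benzyl group of compound 2 and differs elsewhere: 2H-1,2,3-triazol-2-yl in place of hydrogen on a saturated chain carbon bound to an aromatic carbon. Cut one bond further out, the same difference reads methyl to (2H-1,2,3-triazol-2-yl)methyl.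

Within the data shown here, the only measured step is an at least 2.8-fold lower number from compound 1 to compound 2 (0.45 log units; beyond the scatter). That step concerns benzyl in place of 4-chlorophenyl on an aromatic nitrogen, not the place changed here, so it offers only a rough guide to what a single change can do in this series and no direct size for this one. A modest step at most is expected in this assay, leaning towards a higher number, and a reading that is again only a limit remains possible. The expected step is an at least 1.2-fold higher number from compound 2 to compound 3 (0.09 log units; that floor lies within the scatter). For compound 3 the estimated value is 10 mL.min-1.g-1, with an expected range from 4 mL.min-1.g-1 to 28 mL.min-1.g-1.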

Compound 3, intrinsic clearance in microsomes: 19 mL.min-1.g-1
The estimate for compound 3 lay 1.9-fold (0.28 log units) below the measured number; the range from low to high includes it.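

In this assay, among these compounds, the first reading at this place shows that it is not silent: with the benzyl group held constant, 2H-1,2,3-triazol-2-yl in place of hydrogen on a saturated chain carbon bound to an aromatic carbon gives an at least 2.3-fold higher number from compound 2 to compound 3 (0.37 log units; beyond the scatter). Compound 3, at 19 mL.min-1.g-1, gives the benzyl compounds their first full number, so further changes at this place can be read from compound 3 as sizes. The size of the step just given is only a floor, and the true step may be larger, because compound 2 stands at a limit of the assay and not at a number: the limit of < 8 mL.min-1.g-1 in this assay, at which 1 of the 3 values shown sits.

One pair cannot show whether the higher number belongs to the 2H-1,2,3-triazol-2-yl ring itself or would follow from other groups on the same carbon, such as an amine, a carboxylic acid or a longer chain. From the compounds shown here alone, it also remains open whether the same change would move the number in the same direction with the 4-chlorophenyl group of compound 1 in place of benzyl.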